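The source may hold more compounds than are shown below. What is called first, only, known or untested is meant among the compounds shown, and "the series" means these compounds.

Among the measured compounds shown here, compound 2 `CCC(C)/N=C(\C)c1c(O)c2ccccc2[nH]c1=O` is one of three compounds measured so far in an assay on isolated protein for inhibition of myosin-2 (Bos taurus), read by spectrophotometry, with a stated time of 24 min; on this read-out lower numbers stand for stronger inhibition and higher numbers for weaker inhibition. For the measured compounds named here, for compound 2 this assay reports only a limit, >= 100000 nM, and no number; it is the one value of the three that sits at the limit (the limit of >= 100000 nM in this assay, at which 1 of the 3 values shown sits). Compound 1 `C/C(=N\Nc1ccccc1)c1c(O)c2ccccc2oc1=O` gives 27000 nM in this assay. Going by the values given here, compound 3 `CCCCC/N=C(\C)c1c(O)c2ccccc2oc1=O` gives 6700 nM in this assay, and the single change measured in one place is a 4.0-fold lower number from compound 1 to compound 3 (0.61 log units; beyond the scatter).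

Compound 4 `CCCC/N=C(\C)c1c(O)c2ccccc2[nH]c1=O` has not yet been measured in this assay. It differs from compound 2 in one place: butyl in place of sec-butyl on a double-bonded nitrogen. Among the compounds with values here, no measured step exchanges one chain for another of the same count on the double-bonded nitrogen, so the step from compound 1 to compound 3, which replaces an anilino by a pentyl, is only a loose guide, and it was modest. The starting point, compound 2, is a limit rather than a number, so any step from it can only be read toward a number that may or may not appear. Compound 4 is expected to give about 50000 nM in this assay, with a range from 12000 nM to 200000 nM. The expected step is therefore an at least 2.0-fold lower number from compound 2 to compound 4 (0.30 log units; that floor lies within the scatter), with a real chance that this assay again reports only a limit.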

Compound 4, half-maximal inhibitory concentration: >= 100000 nM
Compound 4 was reported as a limit; the forecaster's own chance of this, stated with the estimate: 40%; middle value at least 2.0-fold (0.30 log units) away from the limit.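

Compound 2 and compound 4 are both reported only as a limit and not as a number, so no step between them can be read: the limit of >= 100000 nM in this assay, at which 2 of the 4 values shown sit.

The compounds shown leave open whether butyl and sec-butyl on a double-bonded nitrogen differ at all in this assay.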